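The compounds below may be only part of what the source reports. "The series", "measured", "known", "first", "only" and "open" are said of these compounds alone.

Three compounds from this series have been run in a physicochemical assay for lipophilicity, at pH 7.4 (a higher number here means a more lipophilic compound, a lower number a more polar compound), so far. Compound 1, `COc1cc(-c2nc3n(n2)CCCC3c2ccc(Cl)c(Cl)c2)ccc1-c1cnc(C)o1`, gives 4.4 in this assay. Compound 2, `COc1cc(-c2nnc3n2CCC=C3c2ccc(Cl)c(Cl)c2)ccc1-c1cnc(C)o1`, gives 3.6, and compound 3, `COc1cc(-c2nnc3n2CCCC3c2ccc(C(F)(F)F)cc2)ccc1-c1cnc(C)o1`, gives 2.9. On these numbers compound 3 stands lowest of the three: compound 2 is the nearest to it and lies higher by an amount beyond the usual scatter, and compound 1 lies higher still, again beyond the scatter. Going by the values given here, none of the three pairs differs in a single place, so no step between measured compounds can be read off directly.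

The next compound, compound 4, `COc1cc(-c2nnc3n2CCCC3c2cccc(C(F)(F)F)c2)ccc1-c1cnc(C)o1`, is built from compound 3 with the same atoms joined differently: 3-(trifluoromethyl)phenyl in place of 4-(trifluoromethyl)phenyl on a saturated ring carbon. Among the compounds with values here, since nothing in the set so far isolates such a move of a trifluoromethyl group around its ring, there is no measured step to lean on, and the step from compound 3 to compound 4 is expected to be small, no change at the digits printed from compound 3 to compound 4 (within the scatter), with no change beyond the scatter in either direction. On that basis compound 4 is estimated at 2.9 in this assay, with a likely range from 2.5 to 3.3.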

Compound 4, distribution coefficient: 2.8
Beside the measured number, compound 4's estimate is 0.10 log units above it; low and high end bracket the measured number.
By their numbers in this assay, from the lowest: compounds 4 and 3 (each within the scatter of the next); then compound 2; then compound 1.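

In this assay, moving the trifluoromethyl group around its ring on this saturated ring carbon gives a number 0.10 log units lower from compound 3 to compound 4 (within the scatter) and this is the only pair shown that differs in one place. Going by these compounds alone, at this position, on the core of compound 3, 3-(trifluoromethyl)phenyl and 4-(trifluoromethyl)phenyl therefore cannot be told apart in this read-out, something the earlier compounds could not show, as no single-place step could be read among them. Nothing measured in this set accounts for the two placements reading alike, and this one pair does not make a rule for other groups or other cores.

The compounds leave open whether the same holds when a different group is moved around that ring, such as a nitrile, a methoxy group or a single chlorine atom, or when the phenyl ring carries no group at all. Compound 1 and compound 2 each differ from compound 3 and compound 4 in more than one place, so the steps between them cannot be read and what lies behind those gaps in this assay stays unassigned.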